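Chloro added to the trifluoromethylphenyl urea of compound 2

A few compounds are considered here, and "the series" means these few. Any claim that something is new, unique, unknown or untested is made for them only; others in the source may bear on it.

Within the data shown here, compound 2 `COc1cc2cc(Oc3ccc(NC(=O)Nc4cccc(C(F)(F)F)c4)cc3)c(C)nc2cc1OC` gives 0.81% in a functional assay on MOLT-4 cells (Homo sapiens) for inhibition, read by sulforhodamine B assay, with a stated time of 48 h, tested at 10 uM (on this read-out lower numbers stand for a stronger effect and higher numbers for a weaker effect at the one concentration tested), and stands lowest of the two numbers so far; the nearest is compound 1 `COc1cc2cc(Oc3ccc(NC(=O)Nc4ccc(C)cc4)cc3)c(C)nc2cc1OC`, which in this assay gives 82.4%. Among the measured compounds shown here, the only measured step, a number 81.6 percentage points lower from compound 1 to compound 2 (beyond the scatter), shows how far the read-out moves when the group on the amide-type nitrogen is exchanged. Compound 3 `COc1cc2cc(Oc3ccc(NC(=O)Nc4ccc(Cl)c(C(F)(F)F)c4)cc3)c(C)nc2cc1OC` differs from compound 2 by chloro in place of hydrogen on an aromatic carbon, on an aromatic carbon ortho to the trifluoromethyl group and para to a large group. For the measured compounds named here, no measured step covers the entry of a chloro on this ring, so the single step bears only indirectly: it places compound 2 at the floor of the read-out, leaving little room for a further fall. For compound 3 in this assay a step of a number 1.7 percentage points higher from compound 2 to compound 3 (within the scatter) is expected, within the scatter. Compound 3 is estimated at 2.5%, between 0% and 15%.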

Compound 3, a percentage reported as activity, at one concentration (the size of the read-out at that concentration, not a potency): -27.9%
Beside the measured number, compound 3's estimate is 30.4 percentage points above it, and the stated range ends above it.
By their numbers in this assay, from the lowest: compound 3; then compound 2; then compound 1.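

In this assay, chloro in place of hydrogen on an aromatic carbon, ortho to a trifluoromethyl group and para to a large group, gives a number 28.7 percentage points lower from compound 2 to compound 3 (beyond the scatter). The read-out therefore still responds to substitution at this position after the low value of compound 2 and continues past zero, with compound 3 at -27.9%, while the full exchange to 4-chloro-3-(trifluoromethyl)phenyl gives a number 110.3 percentage points lower from compound 1 to compound 3 (beyond the scatter). The data at hand offer no explanation for the chloro step.

Open, on these data alone, is whether this step belongs to chloro itself or would also appear with a fluoro, a methoxy or a nitrile at the same position. Also open, as far as these compounds go, is whether chloro gives a similar step without the trifluoromethyl group, as in a 4-chlorophenyl urea.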